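The source may report more compounds than this note shows. Statements on the series, on what has been measured and on what is new or still open speak of the compounds shown alone.

Compound 1, `COc1cc2c(Oc3ccc(NC(=O)c4cn(-c5c(C)cccc5C)nn4)cc3F)ccnc2cc1OCCCN1CCCCC1`: in a functional assay on HT-29 cells (Homo sapiens) for cytotoxicity, read by MTT assay, with a stated time of 72 h (on this read-out lower numbers stand for stronger inhibition and higher numbers for weaker inhibition), compound 1 gives 3690 nM.
Compound 2, `COc1cc2c(Oc3ccc(NC(=O)c4cn(-c5c(Cl)cccc5Cl)nn4)cc3F)ccnc2cc1OCCCN1CCCCC1`: in this assay compound 2 gives 240 nM.
Compound 3, `COc1cc2c(Oc3ccc(NC(=O)c4cn(-c5ccc(F)c(F)c5)nn4)cc3F)ccnc2cc1OCCCN1CCCCC1`: in this assay compound 3 gives 210 nM.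

Compound 3 has the lowest number of the three, but its gap to compound 2 is within the scatter, so the two cannot be ranked; only compound 1 stands clearly apart, as the steps of a 15-fold lower number from compound 1 to compound 2 (1.19 log units; beyond the scatter) and an 18-fold lower number from compound 1 to compound 3 (1.24 log units; beyond the scatter) show, both large, against a 1.1-fold lower number from compound 2 to compound 3 (0.06 log units; within the scatter).

Compound 4, `COc1cc2c(Oc3ccc(NC(=O)c4cn(-c5ccc(F)c(F)c5)nn4)cc3F)ccnc2cc1OCCCN1CCC(C)CC1`, is not yet measured. It differs from compound 3 by methyl in place of hydrogen on a saturated ring carbon. Every measured step changed the group on the aromatic nitrogen of the shared core; none touched the saturated ring. So no measured step bears on this change, and there is no basis for expecting a shift in either direction in this assay. The expected step is therefore within the scatter, a 1.0-fold higher number from compound 3 to compound 4 (0.02 log units; within the scatter), with compound 4 estimated at 220 nM, between 90 nM and 550 nM.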

Compound 4, half-maximal inhibitory concentration: 810 nM
Compound 4: the middle estimate sits 3.7-fold (0.57 log units) below what was measured; the whole stated range lies below it.
By their numbers in this assay, from the lowest: compounds 3 and 2 (each within the scatter of the next); then compound 4; then compound 1.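

Compound 3 and compound 4 differ only at the far end of the molecule, where piperidin-1-yl becomes 4-methylpiperidin-1-yl, and this single added methyl gives a 3.9-fold higher number from compound 3 to compound 4 (0.59 log units; beyond the scatter) in this assay. Going by these compounds alone, the saturated ring is therefore not a silent part of the structure in this cytotoxicity read-out: a change of one carbon, three ring bonds from the ring nitrogen, moves the number towards weaker inhibition, something the earlier steps on the aromatic nitrogen could not reveal. Nothing available here explains this shift.

On these data alone, whether an ethyl or a hydroxyl group on the same ring carbon would move the number further, less or the other way remains open. So does whether the methyl has a similar effect when the 3,4-difluorophenyl group is replaced by 2,6-dichlorophenyl.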